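A Methylpiperazine for Piperidine on the Hydroxyphenyl Core

A few compounds are considered here, and "the series" means these few. Any claim that something is new, unique, unknown or untested is made for them only; others in the source may bear on it.

Compound 3 `Oc1ccc(-c2nc(N3CCCCC3)c3nc[nH]c3n2)cc1` stands at the ceiling of an assay on cells for displacement of a labelled ligand from adenosine receptor A1 (Homo sapiens), read by scintillation counting and radioligand binding, with a stated time of 60 min, tested at 10 uM; on this read-out lower numbers stand for less inhibition and higher numbers for more inhibition at the one concentration tested (going by the name of the read-out): compound 3 gives > 80%, which is a limit of the assay and not a number. Compound 1 `CN1CCN(c2nc(-c3ccc(Cl)c(Cl)c3)nc3[nH]cnc23)CC1` gives > 80%, also a limit. Compound 2 `CN1CCN(c2nc(-c3ccc(Cl)cc3)nc3[nH]cnc23)CC1` gives > 80%, again a limit. Going by the values given here, the only measured step, a step that the two limits leave unreadable from compound 1 to compound 2, cannot be read because the limit of > 80% in this assay, at which 3 of the 3 values shown sit, holds all three values. Compound 4 `CN1CCN(c2nc(-c3ccc(O)cc3)nc3[nH]cnc23)CC1` differs from compound 3 by 4-methylpiperazin-1-yl in place of piperidin-1-yl on an aromatic carbon. Among the compounds with values here, no measured step bears on this change; compounds 1 and 2 carry the entering group and both sit at the limit. Compound 4 is therefore expected to reach the limit again, an expected step that the limit leaves unreadable from compound 3 to compound 4. The estimate for compound 4 in this assay is 86%, between 70% and 96%.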

Compound 4, a percentage reported as inhibition, at one concentration (the size of the read-out at that concentration, not a potency): > 80%
Compound 4: a limit, no number (the forecaster's own chance of this, stated with the estimate: 75%); the middle value lies beyond the limit too.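

Going by these compounds alone, no step from compound 1, compound 2 or compound 3 to compound 4 can be read in this assay, because the values stop at a limit: the limit of > 80% in this assay, at which 4 of the 4 values shown sit. The compounds shown leave open whether any of these changes alters inhibition, and by how much.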